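Changing the group on the amide carbonyl: an efficacy estimate

The source may report more compounds than this note shows. Statements on the series, on what has been measured and on what is new or still open speak of the compounds shown alone.

Measured compounds:
compound 1 `CCC(=O)Nc1c(C(O)(C(F)(F)F)C(F)(F)F)ccc2ccccc12` gives 96% in a functional assay (Sus scrofa) with sulfonylurea receptors; K-ATP channels (Homo sapiens) as the target; on this read-out lower numbers stand for smaller maximal responses and higher numbers for larger maximal responses
compound 2 `O=C(Nc1c(C(O)(C(F)(F)F)C(F)(F)F)ccc2ccccc12)c1cccc([N+](=O)[O-])c1` gives 99% in this assay

Among the measured compounds shown here, compound 2 holds the highest of the two numbers in this assay, with compound 1 nearest; the only measured step, a number 3 percentage points higher from compound 1 to compound 2 (within the scatter), lies within the scatter, so the two compounds cannot be ordered on these numbers. That step put a 3-nitrophenyl in place of an ethyl on the carbonyl carbon.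

Compound 3 `O=C(Nc1c(C(O)(C(F)(F)F)C(F)(F)F)ccc2ccccc12)c1cccnc1` is not yet measured. It differs from compound 2 by pyridin-3-yl in place of 3-nitrophenyl on a carbonyl carbon. For the measured compounds named here, the one measured step bears on this change only in that it also exchanges the group on the carbonyl carbon whose other neighbour is the amide-type nitrogen, and that exchange left the maximal response unchanged within the scatter. On this basis compound 3 is expected to show no step beyond the scatter, a number 4 percentage points lower from compound 2 to compound 3 (within the scatter). The estimate for compound 3 in this assay is 95%, with a range from 80% to 105%.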

Compound 3, largest response reached (reported as efficacy), in percent of the reference or control that the assay uses: 97%
Compound 3: the middle estimate sits 2 percentage points below what was measured; low and high end bracket the measured number.
By their numbers in this assay, from the lowest: compounds 1, 3 and 2 (each within the scatter of the next).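

In this assay, pyridin-3-yl in place of 3-nitrophenyl on the carbonyl carbon whose other neighbour is the amide-type nitrogen gives a number 2 percentage points lower from compound 2 to compound 3 (within the scatter) even though the entering group has 6 heavy atoms against 9 for the leaving group, and its six-membered aromatic ring carries 1 hetero atom where the leaving ring has carbon only. Pyridin-3-yl in place of ethyl gives a number 1 percentage points higher from compound 1 to compound 3 (within the scatter) and so adds a third group at this place, and the three compounds cannot be told apart on these numbers. No measured evidence is at hand that could speak to this result.

What the compounds shown leave open is whether any group on this carbonyl carbon moves the maximal response beyond the scatter, since every group seen here, one chain and two aromatic rings, gives a closely matching number. A longer alkyl chain, a saturated ring such as cyclohexyl, a phenyl carrying an amine or a pyridine joined through its other ring carbons could show whether this sameness holds beyond ethyl, 3-nitrophenyl and pyridin-3-yl.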